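A few compounds are considered here, and "the series" means these few. Any claim that something is new, unique, unknown or untested is made for them only; others in the source may bear on it.

Measured in a functional assay on DLD-1 cells (Homo sapiens) for cytotoxicity, read by MTT assay; a lower number here means a stronger inhibitor, a higher number a weaker inhibitor
- compound 1 `COc1cc(/C=C/C(=O)C(=Cc2ccc(OC)c(OC)c2)C(=O)/C=C/c2ccc(O)c(OC)c2)ccc1O` gives 3070 nM
- compound 2 `CCOc1cc(C=C(C(=O)/C=C/c2ccc(O)c(OC)c2)C(=O)/C=C/c2ccc(O)c(OC)c2)ccc1O` gives 4260 nM
- compound 3 `COc1cc(/C=C/C(=O)C(=Cc2ccc(O)c(O)c2)C(=O)/C=C/c2ccc(O)c(OC)c2)ccc1O` gives 17600 nM

Compound 2 sits at the lower end of this short range, level with compound 1: the step of a 1.4-fold higher number from compound 1 to compound 2 (0.14 log units; within the scatter) shows no separation, while the step of a 4.1-fold higher number from compound 2 to compound 3 (0.62 log units; beyond the scatter) is a real one.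

The change under consideration leads to compound 4 `COc1cc(/C=C/C(=O)C(=Cc2ccccc2)C(=O)/C=C/c2ccc(O)c(OC)c2)ccc1O` and is described by phenyl in place of 3-ethoxy-4-hydroxyphenyl on a double-bonded chain carbon bound to a double-bonded chain carbon. Going by the values given here, all the measured steps act at this same place. Trading one substituted ring for another gave a 1.4-fold higher number from compound 1 to compound 2 (0.14 log units; within the scatter) in one case and a 5.7-fold higher number from compound 1 to compound 3 (0.76 log units; beyond the scatter) in the other, so only compound 3 moves away from the other two. Among the compounds with values here, none of the measured compounds has a bare phenyl at this place, so the evidence is indirect and the range must stay wide. In this assay the expected step is a 1.2-fold higher number from compound 2 to compound 4 (0.07 log units; within the scatter), which would stay within the scatter, with a slightly higher number if anything. The estimate for compound 4 is 5000 nM (expected range 1800 nM to 14000 nM).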

Compound 4, half-maximal inhibitory concentration: 5450 nM
The estimate for compound 4 lay 1.1-fold (0.04 log units) below the measured number; the range from low to high includes it.
By their numbers in this assay, from the lowest: compounds 1, 2 and 4 (each within the scatter of the next); then compound 3.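

In this assay, replacing the substituted ring with bare phenyl on a double-bonded chain carbon bound to a double-bonded chain carbon gives a 1.3-fold higher number from compound 2 to compound 4 (0.11 log units; within the scatter) and a 1.8-fold higher number from compound 1 to compound 4 (0.25 log units; within the scatter), so compound 4 is not separated from either compound. Among these compounds, then, neither the 3-ethoxy-4-hydroxyphenyl nor the 3,4-dimethoxyphenyl ring shows an advantage over the unsubstituted ring, while a 3.2-fold lower number from compound 3 to compound 4 (0.51 log units; beyond the scatter) sets the 3,4-dihydroxyphenyl compound apart from bare phenyl and makes compound 3 the one exception in the series of four. No measurement at hand accounts for this separation or for the flat result among the other three compounds.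

The compounds shown leave open how an amine or a carboxylic acid on the ring at this place would read in this assay, and whether the level of compound 2 would hold with a longer chain in place of the ethyl on the oxygen. Also open, as far as these compounds go, is whether a phenyl with a single hydroxyl would read with compound 3 or with compound 4.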